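Notes on compound 1 and its propylamino analogue

The source may hold more compounds than are shown below. What is called first, only, known or untested is meant among the compounds shown, and "the series" means these compounds.

compound 1 `CCC(=O)Nc1ccc(C2=NNC(=O)CC2)cc1`: 0.64 ug/mL
compound 2 `CC(=O)Nc1ccc(C2=NN(C)C(=O)CC2)cc1`: > 46.4 ug/mL (a limit)
compound 3 `CC(=O)Nc1ccc(C2=NNC(=O)C(C)C2)cc1`: 46.4 ug/mL

In a functional assay for inhibition, with Homo sapiens as the target (on this read-out higher numbers stand for an effect only at larger amounts of compound and lower numbers for an effect already at smaller amounts), compound 1 has the lowest number, 0.64 ug/mL. Compound 3 gives 46.4 ug/mL, a higher number and beyond the scatter. Compound 2 gives > 46.4 ug/mL, which is a limit of the assay and not a number.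

Compound 4 `CCCNCC(=O)Nc1ccc(C2=NNC(=O)CC2)cc1` has not yet been measured. It has propylamino in place of methyl on a saturated chain carbon bound to a carbonyl carbon. Within the data shown here, no measured step covers this change, so the expectation is loose. A moderate rise beyond the scatter is expected, since compound 1 already sits lowest at 0.64 ug/mL. The estimated step is a 9.4-fold higher number from compound 1 to compound 4 (0.97 log units; beyond the scatter). For compound 4 the estimated value is 6 ug/mL, with an expected range of 0.8 ug/mL to 46 ug/mL.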

Compound 4, half-maximal effective concentration: about 46.4 ug/mL
Compound 4: middle estimate off by 7.7-fold (0.89 log units), on the low side; the measured number lies above the stated range.
By their numbers in this assay, from the lowest: compound 1; then compounds 3 and 4 (each within the scatter of the next).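

Propylamino in place of methyl on a saturated chain carbon bound to a carbonyl carbon is poorly tolerated in this assay, giving a 73-fold higher number from compound 1 to compound 4 (1.86 log units; beyond the scatter). Among these compounds, this is the first measured change at this end of the molecule. Compound 2 stands at a limit in this assay, and the reading for compound 4 lies at the same figure, so this step may sit at the edge of what can be read: the limit of > 46.4 ug/mL in this assay, at which 1 of the 4 values shown sits.

Going by these compounds, whether the rise follows the amine nitrogen or the longer chain stays open. A plain butyl chain or a small dimethylamino group at this place would tell the two apart.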